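Nitro in place of methyl: expectation for compound 3

The compounds below may be only part of what the source reports. "The series", "measured", "known", "first", "only" and "open" are said of these compounds alone.

Going by the values given here, in a functional assay on MDA-MB-231 cells (Homo sapiens) for antiproliferative activity, read by MTT assay, with a stated time of 72 h (a lower number here means a stronger inhibitor, a higher number a weaker inhibitor), compound 2 `COc1cc(-c2nccn2-c2cccc(C)c2)cc(OC)c1OC` gives 11700 nM, the only value so far that is a true number. Compound 1 `CCCn1ccnc1-c1cc(OC)c(OC)c(OC)c1` reports only a limit, > 100000 nM.

The next structure, compound 3 `COc1cc(-c2nccn2-c2cccc([N+](=O)[O-])c2)cc(OC)c1OC`, keeps the core of compound 2 and carries nitro in place of methyl on an aromatic carbon, meta to a large group (nitro in place of methyl on an aromatic carbon).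

One measured step is available: an at least 8.5-fold lower number from compound 1 to compound 2 (0.93 log units; beyond the scatter). Its size rests on (the limit of > 100000 nM in this assay, at which 1 of the 2 values shown sits), and it concerns the group on the aromatic nitrogen, not a substituent on the six-membered aromatic ring of carbon only. Among the compounds with values here, it therefore bears on the new change only indirectly, and no measured step shows the effect of a change at this place. No direction can be read from the data, so the working expectation in this assay is no shift beyond the scatter, with wide uncertainty on both sides. The expected step is a 1.2-fold higher number from compound 2 to compound 3 (0.08 log units; within the scatter). For compound 3 the estimated value is 14000 nM, with an expected range of 4000 nM to 45000 nM.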

Compound 3, half-maximal inhibitory concentration: > 100000 nM
Compound 3 gave a limit, no number; the forecaster's own chance of this, stated with the estimate: 8%; middle value at least 7.1-fold (0.85 log units) from the limit.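

The replacement of methyl by nitro on an aromatic carbon of the six-membered aromatic ring of carbon only, meta to a large group, gives an at least 8.5-fold higher number from compound 2 to compound 3 (0.93 log units; beyond the scatter), and this is the only step shown at this place. The place is therefore not indifferent to its substituent: with the rest of compound 2 held constant, this single change is enough to take this assay from a true number to a reading with no number. Compound 3 gives > 100000 nM, which is a limit and not a number, so only a minimum size is known for the step because of where the values sit: the limit of > 100000 nM in this assay, at which 2 of the 3 values shown sit.

With a single pair at this place, the compounds shown leave open whether the loss is specific to nitro or would also appear with other groups there, such as an amine, a carboxylic acid or a single chlorine atom. Also open, as far as these compounds go, is whether any group at this place can give a lower number in this assay than compound 2, which stands at 11700 nM.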